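Swapping one aryl group on a high-stability compound

The compounds below may be only part of what the source reports. "The series", "measured", "known", "first", "only" and "open" are said of these compounds alone.

Compound 1 `CCCCN(Cc1ccc(OCCn2c(=O)ccn(C)c2=O)c(OC)c1)C(CC(=O)O)c1ccc(Cl)cc1` gives 37% remaining
Compound 2 `CCCN(Cc1ccc(OCCn2c(=O)ccn(C)c2=O)c(OC)c1)C(CC(=O)O)c1ccc2c(c1)CCO2` gives 89% remaining
Compound 3 `COc1cc(CN(CC(C)C)C(CC(=O)O)c2ccc3c(c2)CCO3)ccc1OCCN1C(=O)CCC1=O` gives 100% remaining

These numbers come from an ADME assay on liver (Mus musculus) for metabolic stability, read by LC-MS, using microsomes and NADPH; a lower number here means that less of the compound is left, a higher number that more of the compound is left. Compound 3 stands highest of the three, and both other compounds lie lower by more than the usual scatter. The next compound to be tested is compound 4 `COc1cc(CN(CC(C)C)C(CC(=O)O)c2ccc(Cl)cc2)ccc1OCCN1C(=O)CCC1=O`, which is made from compound 3 by one structural change: a group of 7 heavy atoms (6 carbon, 1 chlorine; one six-membered aromatic ring of carbon only) in place of a group of 9 heavy atoms (8 carbon, 1 oxygen; one five-membered non-aromatic ring with 1 hetero atom, one six-membered aromatic ring of carbon only), on a saturated chain carbon bound to an amine nitrogen and a saturated chain carbon. In plain terms, a 4-chlorophenyl group takes the place of a group with no common name, on a saturated chain carbon bound to an amine nitrogen and a saturated chain carbon.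

Within the data shown here, no measured pair differs in one place only, so the evidence is indirect. Compound 2 carries the same group that leaves here and gives 89% in this assay. Compound 1 carries the 4-chlorophenyl group and gives 37% in that test. Compound 1 also differs from compound 3 elsewhere, so only part of that gap may belong to this group. A fall beyond the scatter is therefore expected, with the estimated step of a number 37 percentage points lower from compound 3 to compound 4 (beyond the scatter) in this assay. The estimate for compound 4 is 63% (expected range 38% to 88%).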

Compound 4, percent of the compound remaining: 69%
For compound 4 the middle estimate is 6 percentage points below the measured one; the measured number falls inside the stated range.
By their numbers in this assay, from the lowest: compound 1; then compound 4; then compound 2; then compound 3.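

In this assay, among these compounds, the change to a 4-chlorophenyl group gives a number 31 percentage points lower from compound 3 to compound 4 (beyond the scatter) and this is the first reading in which only this group differs, with the rest of the molecule held fixed. The earlier compounds shown here could only hint at an effect here, since compound 1 and compound 2 differ from compound 3 in more than one place; the pair now shows that the group on the saturated chain carbon bound to an amine nitrogen and a saturated chain carbon by itself moves the amount of compound left by a large step. The results show how large the step is, but no measurement at hand explains why the two groups differ.

Whether a step of this size would also appear with the amine chains and the ring-bearing side chain of compound 1 and compound 2 stays open, as no pair among the compounds shown tests the swap in that setting. Also open, going by these compounds, is how a plain phenyl, 4-fluorophenyl or 4-methoxyphenyl group would stand at this place, which would help separate the role of the chlorine from that of the ring with the oxygen atom.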